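The source may hold more compounds than are shown below. What is called first, only, known or untested is meant among the compounds shown, and "the series" means these compounds.

Four compounds are compared in a functional assay on PC-3 cells (Homo sapiens) for cytotoxicity, read by MTT assay, with a stated time of 72 h; a higher number here means a weaker inhibitor of growth, a lower number a stronger inhibitor of growth. Compound 1 `N#CSCN1C(=O)c2ccccc2C1=O` and compound 2 `N#C[Se]CN1C(=O)c2ccccc2C1=O` share one core, while compound 3 `N#CSCc1ccc(-n2cccc2)cc1` and compound 4 `N#C[Se]Cc1ccc(-n2cccc2)cc1` share another, and the difference between the two cores is not broken down here. In this assay compound 1 gives only a limit, > 100000 nM. Compound 2 gives 11200 nM in this assay, and compound 3 gives 14100 nM there. Among the compounds with values here, the change between the first pair is a group of 3 heavy atoms (1 carbon, 1 nitrogen, 1 selenium; no ring) in place of a group of 3 heavy atoms (1 carbon, 1 nitrogen, 1 sulfur; no ring), on a saturated chain carbon bound to an amide-type nitrogen in a ring, and it gave an at least 8.9-fold lower number from compound 1 to compound 2 (0.95 log units; beyond the scatter); the true size of that step is not known because of the limit of > 100000 nM in this assay, at which 1 of the 3 values shown sits. The change within the second pair is a group of 3 heavy atoms (1 carbon, 1 nitrogen, 1 selenium; no ring) in place of a group of 3 heavy atoms (1 carbon, 1 nitrogen, 1 sulfur; no ring), on a saturated chain carbon bound to an aromatic carbon, the same kind of change, though here it sits on a saturated chain carbon bound to an aromatic carbon rather than one bound to an amide-type nitrogen in a ring. Resting on the earlier step of an at least 8.9-fold lower number from compound 1 to compound 2 (0.95 log units; beyond the scatter), a smaller but still clear drop is expected, namely a 4.0-fold lower number from compound 3 to compound 4 (0.61 log units; beyond the scatter). The estimate for compound 4 in this assay is 3500 nM, expected to lie between 900 nM and 13000 nM.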

Compound 4, concentration for 50% growth inhibition: 59900 nM
Compound 4: the middle estimate sits 17-fold (1.23 log units) below what was measured; measured number above the stated range.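

In this assay the change from the cyanosulfanyl group to the selenium-bearing group did not carry over from one core to the other: on a saturated chain carbon bound to an aromatic carbon it gave a 4.2-fold higher number from compound 3 to compound 4 (0.63 log units; beyond the scatter) and so ran opposite to the drop seen on the other core, and the two steps differ clearly: the same change on two cores in this assay, an at least 8.9-fold lower number (0.95 log units; beyond the scatter) from compound 1 to compound 2 and a 4.2-fold higher number (0.63 log units; beyond the scatter) from compound 3 to compound 4, at least 37-fold (1.57 log units) apart, beyond the scatter of two such steps. The full gap between them is not known, as compound 1 gives only a limit: the limit of > 100000 nM in this assay, at which 1 of the 4 values shown sits. The result shows that, in these two pairs, the direction of this change depends on the core, but it does not show which part of either core is responsible, and two pairs give no rule for the whole series.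

From the compounds shown here alone, it remains open whether a longer chain between either core and the selenium-bearing group would follow the direction of compound 2 or that of compound 4. Going by these compounds, it is also open whether an amine or a carboxylic acid on either core would alter the outcome of this change.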